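The compounds below may be only part of what the source reports. "The series", "measured", "known", "first", "only" and "open" are said of these compounds alone.

In an ADME assay on cells (Macrophage) for cytotoxicity, read by MTT assay, with a stated time of 24 h (a lower number here means that less compound is tolerated, a higher number that more compound is tolerated), compound 2 `COc1ccc(/C=C/C(=O)NNC(=O)c2ccc3c(c2)OCCO3)cc1` gives 319000 nM and compound 1 `O=C(/C=C/c1ccc(Br)cc1)NNC(=O)c1ccc2c(c1)OCCO2` gives 259000 nM, so the two lie within the scatter of each other. Compound 3 `COc1cccc(/C=C/C(=O)NNC(=O)c2ccc3c(c2)OCCO3)c1` is the next structure: 3-methoxyphenyl in place of 4-methoxyphenyl on a double-bonded chain carbon bound to a double-bonded chain carbon, with 3-methoxyphenyl in place of 4-methoxyphenyl on a double-bonded chain carbon bound to a double-bonded chain carbon. Within the data shown here, the only measured step, a 1.2-fold higher number from compound 1 to compound 2 (0.09 log units; within the scatter), is a different change, methoxy in place of bromo on an aromatic carbon, so it offers indirect guidance only. The expected result in this assay is no change beyond the scatter, with an expected step of a 1.1-fold lower number from compound 2 to compound 3 (0.04 log units; within the scatter). Compound 3 is estimated at 290000 nM, within a range of 170000 nM to 480000 nM.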

Compound 3, half-maximal cytotoxic concentration: 398000 nM
The estimate for compound 3 lay 1.4-fold (0.14 log units) below the measured number; low and high end bracket the measured number.
By their numbers in this assay, from the lowest: compounds 1, 2 and 3 (each within the scatter of the next).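

In this assay, 3-methoxyphenyl in place of 4-methoxyphenyl gives a 1.2-fold higher number from compound 2 to compound 3 (0.10 log units; within the scatter) and so stays within the scatter, which shows that this position accepts the methoxy group at either ring location named here. 3-Methoxyphenyl in place of 4-bromophenyl gives a 1.5-fold higher number from compound 1 to compound 3 (0.19 log units; within the scatter) and also stays within the scatter, so the three aryl groups cannot be told apart in this assay. No evidence bears on the reason for this result.
Still open, going by these compounds, is whether an amine or a carboxylic acid in place of methoxy on an aromatic carbon would give a step beyond the scatter.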